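A few compounds are considered here, and "the series" means these few. Any claim that something is new, unique, unknown or untested is made for them only; others in the source may bear on it.

Compound 2 `COc1ccc([C@@H]2CC(=O)c3c(O)cc(OCc4cn(Cc5ccc(Cl)cc5)nn4)cc3O2)cc1O` gives 17800 nM in a functional assay on RAW264.7 cells (Mus musculus) for inhibition, read by Griess assay, with stated times of 2 h and 24 h; a higher number here means a weaker inhibitor, a lower number a stronger inhibitor. Compound 1 `C=CCn1cc(COc2cc(O)c3c(c2)O[C@H](c2ccc(OC)c(O)c2)CC3=O)nn1` gives 13800 nM, and the two lie within the scatter of each other, so no ranking can be drawn between them. Compound 3 `COc1ccc([C@@H]2CC(=O)c3c(O)cc(OCc4cn(Cc5ccccc5C)nn4)cc3O2)cc1O` differs from compound 2 by 2-methylphenyl in place of 4-chlorophenyl on a saturated chain carbon bound to an aromatic nitrogen. Going by the values given here, the only measured step at this place, a 1.3-fold higher number from compound 1 to compound 2 (0.11 log units; within the scatter), shows that swapping the group there left the number essentially unchanged. A similar outcome is expected here: no step beyond the scatter in either direction. Compound 3 is therefore estimated at 16000 nM, with a likely range from 7000 nM to 36000 nM. The expected step of a 1.1-fold lower number from compound 2 to compound 3 (0.05 log units; within the scatter) stays within the scatter.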

Compound 3, half-maximal inhibitory concentration: 13100 nM
Compound 3: middle estimate off by 1.2-fold (0.09 log units), on the high side; the measured number falls inside the stated range.
By their numbers in this assay, from the lowest: compounds 3, 1 and 2 (each within the scatter of the next).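

In this assay, 2-methylphenyl in place of 4-chlorophenyl gives a 1.4-fold lower number from compound 2 to compound 3 (0.13 log units; within the scatter), and 2-methylphenyl in place of vinyl gives a 1.1-fold lower number from compound 1 to compound 3 (0.02 log units; within the scatter). On a saturated chain carbon bound to an aromatic nitrogen, then, vinyl and two differently substituted phenyl groups cannot be told apart in this assay, so a methyl-bearing ring does no differently here from a chlorine-bearing one. No measurement at hand explains this. As far as these compounds go, it remains open whether an amine or a carboxylic acid at this place would move the number beyond the scatter.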